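The compounds below may be only part of what the source reports. "The series", "measured", "known", "first", "only" and "open" are said of these compounds alone.

In a functional assay on 3T3-L1 cells (Mus musculus) for inhibition, with a stated time of 20 min, tested at 20 uM (on this read-out lower numbers stand for less inhibition and higher numbers for more inhibition at the one concentration tested (going by the name of the read-out)), compound 3 `CC(=O)N(Cc1cccc(F)c1F)Cc1cn(S(=O)(=O)c2ccc(C)cc2)c2ccccc12` gives 57.5%, the highest of the three numbers; compound 2 `Cc1ccc(S(=O)(=O)n2cc(CN(Cc3cccc(F)c3F)C(=O)C(F)(F)F)c3ccccc32)cc1` gives -5.5% and compound 1 `Cc1ccc(S(=O)(=O)N(Cc2cccc(F)c2F)Cc2cn(S(=O)(=O)c3ccc(C)cc3)c3ccccc23)cc1` gives -13.9%. Compound 4 `Cc1ccc(S(=O)(=O)n2cc(CN(Cc3cccc(F)c3F)S(C)(=O)=O)c3ccccc32)cc1` differs from compound 3 by methylsulfonyl in place of acetyl on an amine nitrogen. For the measured compounds named here, two measured steps bear on this change. The step of a number 71.4 percentage points higher from compound 1 to compound 3 (beyond the scatter) replaced a sulfonyl group on that nitrogen with acetyl, and a number 63 percentage points higher from compound 2 to compound 3 (beyond the scatter) also ended at acetyl. Both show that acetyl on this nitrogen goes with much higher inhibition than the other groups tried, and compound 4 returns a sulfonyl there, though a smaller one than in compound 1. A large fall is therefore expected, a number 42.5 percentage points lower from compound 3 to compound 4 (beyond the scatter). Compound 4 is estimated at 15%, within -15% to 50%.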

Compound 4, a percentage reported as inhibition, at one concentration (the size of the read-out at that concentration, not a potency): -3.3%
Compound 4: the middle estimate sits 18.3 percentage points above what was measured; low and high end bracket the measured number.
By their numbers in this assay, from the lowest: compounds 1, 2 and 4 (each within the scatter of the next, the first and the last beyond it); then compound 3.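

In this assay, the change to methylsulfonyl on the amine nitrogen gives a number 60.8 percentage points lower from compound 3 to compound 4 (beyond the scatter) and so removes nearly all of the number seen with acetyl, which alone among these groups goes with high inhibition. Methylsulfonyl and (trifluoromethyl)carbonyl cannot be told apart, at a number 2.2 percentage points higher from compound 2 to compound 4 (within the scatter) for that exchange, while methyl in place of 4-methylphenyl on the sulfonyl sulfur gives only a number 10.6 percentage points higher from compound 1 to compound 4 (beyond the scatter) and stays far short of acetyl. Nothing available explains these differences. Still open, from the compounds shown here alone, is whether propanoyl, with a longer chain on the carbonyl, or a urea on that nitrogen would hold the number seen with acetyl.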